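The compounds below may be only part of what the source reports. "The series", "measured", "known", "first", "only" and "open" are said of these compounds alone.

Working notes on the series. In a functional assay on HeLa cells (Homo sapiens) for antiproliferative activity, read by cell counting, with a stated time of 2 days (a higher number here means a weaker inhibitor, a lower number a stronger inhibitor), compound 1 (`COc1cc(C(=O)c2sc(N)nc2N)cc(OC)c1OC`) gives 31000 nM as the higher of the two numeric results, and compound 2 (`COc1cc(C(=O)c2sc(N(C)C)nc2N)cc(OC)c1OC`) gives 8200 nM as the lower. Compound 3 (`COc1cc(C(=O)c2sc(N(C)Cc3ccccc3)nc2N)cc(OC)c1OC`) gives > 200000 nM as its result, which is a limit of the assay and not a number.

Compound 4 (`COc1cc(C(=O)c2sc(N3CCCC3)nc2N)cc(OC)c1OC`) differs from compound 1 as follows: pyrrolidin-1-yl in place of amino on an aromatic carbon. The nearest measured precedent is the dimethylamino replacement (a 3.8-fold lower number from compound 1 to compound 2 (0.58 log units; beyond the scatter)), a modest step. The benzyl(methyl)amino replacement (an at least 6.4-fold higher number from compound 1 to compound 3 (0.80 log units; beyond the scatter)) and the phenyl addition (an at least 24-fold higher number from compound 2 to compound 3 (1.38 log units; beyond the scatter)) run the other way, the second of them large. Pyrrolidin-1-yl carries no phenyl, so the expectation follows compound 2 at 8200 nM and not compound 3.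

For compound 4 the estimated step is modest and toward a lower number, namely a 6.2-fold lower number from compound 1 to compound 4 (0.79 log units; beyond the scatter) (expected, not measured). Compound 4 is estimated at 5000 nM with an expected range of 800 nM to 30000 nM (estimate only).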

Compound 4, half-maximal inhibitory concentration: 340 nM
Estimate against measurement, compound 4: 15-fold (1.17 log units) above; the measured number lies below the stated range.
By their numbers in this assay, from the lowest: compound 4; then compound 2; then compound 1. At a limit, above all of these: compound 3.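

At this position, on the aromatic carbon next to the ring nitrogen and next to the ring sulfur, the closed ring goes well beyond the open substituent: pyrrolidin-1-yl in place of amino gives a 91-fold lower number from compound 1 to compound 4 (1.96 log units; beyond the scatter), and pyrrolidin-1-yl in place of dimethylamino gives a 24-fold lower number from compound 2 to compound 4 (1.38 log units; beyond the scatter). Pyrrolidin-1-yl in place of benzyl(methyl)amino gives an at least 580-fold lower number from compound 3 to compound 4 (2.76 log units; beyond the scatter), so among these compounds the number turns on which group the nitrogen carries and not on substitution as such. The result of compound 3 is a limit of the assay and not a number, so that step is a bound only: the limit of > 200000 nM in this assay, at which 1 of the 4 values shown sits.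

Whether the gain belongs to the ring or to its size stays open with a single ring shown. Piperidin-1-yl, azetidin-1-yl or morpholin-4-yl at this carbon would address that, and open-chain diethylamino would set ring against chain.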